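The source may report more compounds than this note shows. Statements on the series, on what has been measured and on what is new or still open speak of the compounds shown alone.

Of the compounds shown here, three have been measured in an ADME assay on HepG2 cells (Homo sapiens) for cytotoxicity, read by CellTiter-Glo and resazurin assay, with a stated time of 72 h; on this read-out higher numbers stand for an effect only at larger amounts of compound and lower numbers for an effect already at smaller amounts. Compound 1 `CC(C)N(Cc1cccc(OCCCCCC(=O)O)c1)C(=O)c1ccc(-c2cccc(Cl)c2)cc1` gives > 21900 nM, which is a limit of the assay rather than a number. Compound 2 `CCOC(=O)CCCCCOc1cccc(CN(C(=O)c2ccc(-c3cnc(OC)nc3OC)cc2)C(C)C)c1` gives > 26000 nM, again a limit. Compound 3 `CCOC(=O)CCCCCOc1cccc(CN(C(=O)c2ccc(-c3ccc4[nH]ccc4c3)cc2)C(C)C)c1` gives > 26000 nM, likewise a limit. Compound 3 thus stands at the edge of what this assay resolves, and all three values sit at limits, as summed up by the limit of > 21900 nM in this assay, at which 1 of the 3 values shown sits, and (the limit of > 26000 nM in this assay, at which 2 of the 3 values shown sit). Among the compounds with values here, the only measured step that changes a single group, a step that the two limits leave unreadable from compound 2 to compound 3, is unreadable, both of its ends being limits. Compound 4 `CCOC(=O)CCCCCOc1cccc(CN(C(=O)c2ccc(-c3cccc(Cl)c3)cc2)C(C)C)c1` differs from compound 3 by 3-chlorophenyl in place of 1H-indol-5-yl on an aromatic carbon. Compound 1 carries the same group that enters here, and its value is also a limit, so nothing in these data points to a step in this assay beyond the scatter in either direction. Compound 4 is therefore expected to give 30000 nM, with a range from 15000 nM to 60000 nM. Compound 4 is expected to show the step that the limit leaves unreadable from compound 3 to compound 4, no larger than the scatter, and most likely it is again reported only as a limit.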

Compound 4, half-maximal effective concentration: > 18400 nM
Compound 4: a limit, no number (the forecaster's own chance of this, stated with the estimate: 85%); the middle value does not contradict the limit.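

Compound 4 is again a limit, like compounds 1, 2 and 3, and none of the steps joining compound 4 to them can be read in this assay. The compounds shown leave open at what concentration any of these four compounds would reach a half-maximal effect.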